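Amide for ketone on the thienopyridine series

This account rests on a few compounds, and the source may have more. Where it says the series, first, only, none or still open, it means among the compounds named here.

Compounds measured so far:
compound 1, `Fc1ccc(CCCc2sc3ncccc3c2-c2ccc(F)cc2)cc1`: 0%
compound 2, `O=C(c1ccc(Cl)cc1)c1sc2ncccc2c1-c1ccc(F)cc1`: 30%

Compound 1 `Fc1ccc(CCCc2sc3ncccc3c2-c2ccc(F)cc2)cc1` carries a three-carbon chain from the shared core to a fluorophenyl group. In an assay on cell membranes for displacement of a labelled ligand from metabotropic glutamate receptor 5 (Rattus norvegicus), tested at 1 uM (on this read-out lower numbers stand for less inhibition and higher numbers for more inhibition at the one concentration tested (going by the name of the read-out)), compound 1 gives 0%. Compound 2 `O=C(c1ccc(Cl)cc1)c1sc2ncccc2c1-c1ccc(F)cc1` instead links a 4-chlorophenyl group through a carbonyl to the same core, and in this assay compound 2 gives 30%. Of the two numbers recorded, compound 2 stands highest; the value of compound 1 lies below it by a gap that is beyond the usual scatter.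

Compound 3 `CN(C(=O)c1sc2ncccc2c1-c1ccc(F)cc1)c1ccc(F)cc1` has not been measured. It differs from compound 2 in one place: (4-fluorophenyl)(methyl)amino in place of 4-chlorophenyl on a carbonyl carbon. Going by the values given here, no step between two measured compounds that differ in this one place is available, so the size of the change in this assay cannot be read from the data. The carbonyl is kept, while the group attached to it changes from an aromatic ring to an amino group bearing a methyl and a 4-fluorophenyl. A modest downward step, a number 10 percentage points lower from compound 2 to compound 3 (within the scatter), is expected, though one near the scatter would not surprise. Compound 3 is estimated at 20%, with a range from 0% to 50%.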

Compound 3, a percentage reported as inhibition, at one concentration (the size of the read-out at that concentration, not a potency): 19%
Compound 3: the middle estimate sits 1 percentage points above what was measured; the measured number falls inside the stated range.
By their numbers in this assay, from the lowest: compound 1; then compound 3; then compound 2.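

In this assay, going by these compounds alone, the change at the carbonyl carbon, from 4-chlorophenyl to (4-fluorophenyl)(methyl)amino, gives the first step that can be read at this position: a number 11 percentage points lower from compound 2 to compound 3 (beyond the scatter). The exchange turns the ketone into an amide, and the reading falls without disappearing, as compound 3 still gives 19% at the one concentration tested. Nothing measured here explains the size of this step.

The single step changes several things at once, adding the amino nitrogen and the methyl and exchanging chlorine for fluorine on the ring, so the compounds shown cannot assign the loss to any one of these parts. On these data alone, it also remains open how the series would respond to a 4-chlorophenyl group on the same amino nitrogen, to the amide hydrogen in place of the methyl, or to a piperidine on the carbonyl carbon, and whether any such amide would match or exceed the reading of the ketone.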